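This account rests on a few compounds, and the source may have more. Where it says the series, first, only, none or still open, it means among the compounds named here.

Measured compounds in a functional assay on HCT-116 cells (Homo sapiens) for inhibition, read by MTT assay, with a stated time of 72 h; on this read-out higher numbers stand for weaker inhibition of growth and lower numbers for stronger inhibition of growth:
- compound 1 `CN1CCN(C(=O)/C=C/c2ccncc2-c2ccc3ccccc3c2)CC1`: > 30000 nM
- compound 2 `NC(=O)/C=C/c1ccncc1Nc1ccc(F)cc1`: "not determined" (no result reported)

Compound 1 stands on no single number in this assay. Its entry of > 30000 nM is a limit of the assay and not a measured value, so its growth inhibition is known only as weaker than that limit, as noted under (the limit of > 30000 nM in this assay, at which 1 of the 2 values shown sits). Compound 2 carries no result in this assay at all. Going by the values given here, no step between measured compounds can therefore be set out, and nothing in the data gives a direction for any change on the shared core of compound 1.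

Compound 3 `CN(C)C(=O)/C=C/c1ccncc1-c1ccc2ccccc2c1` is to be measured in this assay. It differs from compound 1 in one place: dimethylamino in place of 4-methylpiperazin-1-yl on a carbonyl carbon. The 4-methylpiperazin-1-yl on the carbonyl carbon is replaced by dimethylamino, leaving the rest of compound 1 untouched.

Among the compounds with values here, with only a limit for compound 1 and no measured step on the series, no step beyond the scatter is expected in either direction for this change. The expected step is a number no higher from compound 1 to compound 3 (the limit leaves the size open), within the scatter. Compound 3 is expected to land near 30000 nM, between 10000 nM and 100000 nM, most likely again reported as a limit.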

Compound 3, concentration for 50% growth inhibition: 4540 nM
Compound 3: the middle estimate sits 6.6-fold (0.82 log units) above what was measured; measured number below the stated range.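

In this assay, going by these compounds alone, the change to dimethylamino on the carbonyl carbon gives an at least 6.6-fold lower number from compound 1 to compound 3 (0.82 log units; beyond the scatter), which is the first measured step and shows stronger inhibition of growth. This place on the shared core therefore responds to the group it carries: with the double-bonded chain carbon and the rest of compound 1 untouched, the smaller, ring-free dimethylamino gives a single number where 4-methylpiperazin-1-yl gave none. The step has only a lower bound and its full size stays unread, since compound 1 is held by a limit and not a number: the limit of > 30000 nM in this assay, at which 1 of the 3 values shown sits.

The change removes the ring, one nitrogen and part of the heavy-atom count in a single move, so the compounds shown do not tell which of these goes with the stronger inhibition, and a piperidin-1-yl or morpholin-4-yl on the same carbonyl carbon would begin to separate them. Going by these compounds, how far the trend runs among smaller groups also remains open, for example with methylamino or diethylamino at this place, and compound 2, with no result, adds nothing on this.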